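Does the chloro carry the potency of compound 2?

The compounds below may be only part of what the source reports. "The series", "measured", "known", "first", "only" and "open" are said of these compounds alone.

Among the compounds with values here, compound 2 `O=c1c(Cl)c(CSC(=S)N2CCOCC2)oc2ccccc12` gives 4500 nM in a functional assay on HeLa cells (Homo sapiens) for antiproliferative activity, read by MTT assay, with a stated time of 72 h (on this read-out lower numbers stand for stronger inhibition and higher numbers for weaker inhibition), the lowest of the two numbers so far. Within the data shown here, compound 1 `O=c1cc(CSC(=S)N2CCCC2)oc2ccccc12`, the only other compound measured, gives 23100 nM in this assay, a number beyond the scatter from that of compound 2. Compound 3 `O=c1cc(CSC(=S)N2CCOCC2)oc2ccccc12` differs from compound 2 by one change: hydrogen in place of chloro on an aromatic carbon. No measured pair sizes this change, so a step of a 3.1-fold higher number from compound 2 to compound 3 (0.49 log units; beyond the scatter) toward weaker inhibition is expected because the chloro-free compound 1 gives 23100 nM. Compound 3 is therefore estimated at 14000 nM, within 5000 nM to 40000 nM.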

Compound 3, half-maximal inhibitory concentration: 35600 nM
For compound 3 the middle estimate is 2.5-fold (0.41 log units) below the measured one, within the range that was stated.
By their numbers in this assay, from the lowest: compound 2; then compounds 1 and 3 (each within the scatter of the next).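

In this assay, hydrogen in place of chloro on this aromatic carbon gives a 7.9-fold higher number from compound 2 to compound 3 (0.90 log units; beyond the scatter) with the morpholin-4-yl group held fixed, so the chloro does carry much of the potency of compound 2. The step of a 1.5-fold higher number from compound 1 to compound 3 (0.19 log units; within the scatter) for morpholin-4-yl in place of pyrrolidin-1-yl on the thiocarbonyl carbon stays within the scatter, so these two groups are not told apart on the chloro-free core. No available data give a reason for the effect of the chloro. The compounds shown leave open whether fluoro, bromo, methyl or an amine would serve at this carbon, and whether chloro gives a similar step alongside pyrrolidin-1-yl.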